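Exchanging the group on the aromatic nitrogen

The compounds below may be only part of what the source reports. "The series", "measured", "known", "first", "only" and "open" are said of these compounds alone.

Measured in a functional assay on IMR-32 cells (Homo sapiens) for antiproliferative activity, read by MTT assay; on this read-out lower numbers stand for stronger inhibition and higher numbers for weaker inhibition:
- compound 1 `CC1(C)CCc2c(ccc(C(=O)/C=C/c3ccc(OCc4cn(-c5ccc(Br)cc5)nn4)cc3)c2O)O1` gives 117000 nM
- compound 2 `Cc1c(-n2cc(COc3ccc(/C=C/C(=O)c4ccc5c(c4O)CCC(C)(C)O5)cc3)nn2)cccc1[N+](=O)[O-]` gives 73500 nM

Only these two numbers are available, and they cannot be separated. Compound 2, at 73500 nM, stands within the scatter of compound 1.

Compound 3 `COc1ccc(-n2cc(COc3ccc(/C=C/C(=O)c4ccc5c(c4O)CCC(C)(C)O5)cc3)nn2)c([N+](=O)[O-])c1` carries 4-methoxy-2-nitrophenyl in place of 2-methyl-3-nitrophenyl on an aromatic nitrogen. The shared core and its linking chain stay unchanged.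

Among the compounds with values here, one measured step bears on this change: a 1.6-fold lower number from compound 1 to compound 2 (0.20 log units; within the scatter). That step also exchanged the group on the aromatic nitrogen, and it stayed within the scatter. Within the data shown here, it is a single step, and no measured compound carries a methoxy group, so the data give no separate size for that addition.

No shift beyond the scatter is therefore expected in this assay, and no direction can be favoured. The expected change is a 1.1-fold lower number from compound 2 to compound 3 (0.02 log units; within the scatter). For compound 3 the estimated value is 70000 nM, with an expected range of 25000 nM to 180000 nM.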

Compound 3, half-maximal inhibitory concentration: 132000 nM
The estimate for compound 3 lay 1.9-fold (0.28 log units) below the measured number; the measured number falls inside the stated range.
By their numbers in this assay, from the lowest: compounds 2, 1 and 3 (each within the scatter of the next).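

In this assay, within the data shown here, the first compound with a methoxy group still cannot be separated from the other two (a 1.8-fold higher number from compound 2 to compound 3 (0.25 log units; within the scatter); a 1.1-fold higher number from compound 1 to compound 3 (0.05 log units; within the scatter)). All three groups on the aromatic nitrogen, 4-bromophenyl, 2-methyl-3-nitrophenyl and 4-methoxy-2-nitrophenyl, therefore give numbers that lie within the scatter of one another, even though the entering group adds a methoxy group and carries its nitro group at a different place on the ring, so this small set shows no order among these groups at this position. Nothing on hand gives a reason for these numbers.

Going by these compounds, the exchange between compound 2 and compound 3 alters the methyl, nitro and methoxy groups at once, so it remains open what the methoxy group alone contributes at this position. On these data alone, it also remains open whether a group of another kind on the aromatic nitrogen, such as an aminophenyl, a carboxyphenyl or a longer alkyl chain, would move the number beyond the scatter in this assay.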